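The source may hold more compounds than are shown below. What is called first, only, known or untested is meant among the compounds shown, and "the series" means these compounds.

Series notes, step from compound 3 to compound 4.

Compound 1 `C/C(=N\NC(=O)c1cccc(S(=O)(=O)N2CCOCC2)c1)c1ccccc1O` is the reference point of the three measured analogues: in a functional assay on MGC-803 cells (Homo sapiens) for antiproliferative activity, read by MTT assay, with a stated time of 72 h (a lower number here means a stronger inhibitor, a higher number a weaker inhibitor), compound 1 gives 1220 nM. Compound 2 `C/C(=N\NC(=O)c1cccc(S(=O)(=O)N2CCOCC2)c1)c1ccc(O)cc1` gives 71400 nM, and compound 3 `C/C(=N\NC(=O)c1cccc(S(=O)(=O)N2CCOCC2)c1)c1cc(Br)ccc1O` gives 18000 nM. Compound 3 stands second highest of the three numbers, with compound 2 nearest and compound 1 furthest.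

The change now considered is 3-amino-2-hydroxyphenyl in place of 5-bromo-2-hydroxyphenyl on a carbon with a double bond to nitrogen, giving compound 4 `C/C(=N\NC(=O)c1cccc(S(=O)(=O)N2CCOCC2)c1)c1cccc(N)c1O`. Among the measured compounds shown here, two measured steps bear on it. Adding bromine to the ring bearing the hydroxyl, a 15-fold higher number from compound 1 to compound 3 (1.17 log units; beyond the scatter), was a large loss; relocating the hydroxyl, a 59-fold higher number from compound 1 to compound 2 (1.77 log units; beyond the scatter), was a larger loss. For the measured compounds named here, compound 4 keeps the 2-hydroxyphenyl arrangement of compound 1 and removes the bromine, while adding an amino group for which no measured step exists. The removal of bromine alone would be expected to recover much of the loss seen in a 15-fold higher number from compound 1 to compound 3 (1.17 log units; beyond the scatter), so a step in this assay downward, beyond the scatter, is expected: a 6.0-fold lower number from compound 3 to compound 4 (0.78 log units; beyond the scatter). Compound 4 is accordingly estimated at 3000 nM, with a range from 800 nM to 15000 nM.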

Compound 4, half-maximal inhibitory concentration: 530 nM
The estimate for compound 4 lay 5.7-fold (0.75 log units) above the measured number; the measured number lies below the stated range.
By their numbers in this assay, from the lowest: compound 4; then compound 1; then compound 3; then compound 2.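

In this assay, 3-amino-2-hydroxyphenyl on the carbon with a double bond to nitrogen gives the lowest number of the four compounds, with a 34-fold lower number from compound 3 to compound 4 (1.53 log units; beyond the scatter) and a 130-fold lower number from compound 2 to compound 4 (2.13 log units; beyond the scatter). The new finding is that adding to the 2-hydroxyphenyl group need not cost activity: the added amino group gives a 2.3-fold lower number from compound 1 to compound 4 (0.36 log units; beyond the scatter), a modest gain, whereas bromo in place of hydrogen gave a 15-fold higher number from compound 1 to compound 3 (1.17 log units; beyond the scatter). Nothing available explains why these two additions differ in direction.

As far as these compounds go, whether the gain is specific to the amino group remains open, since a dimethylamino, acetamido or methoxy group in its place could give a different number. Also open, from the compounds shown here alone, is whether the step from compound 1 to compound 4 would persist alongside a bromine.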